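The source may hold more compounds than are shown below. What is called first, only, known or untested is meant among the compounds shown, and "the series" means these compounds.

In a functional assay on MOLT-4 cells (Homo sapiens) for inhibition (a lower number here means a stronger inhibitor, a higher number a weaker inhibitor), compound 1 `CC(=O)OCCOn1cnc2c(Cl)nc(N)nc21` gives only a limit, > 500000 nM, and that is a limit rather than a number (the limit of > 500000 nM in this assay, at which 1 of the 3 values shown sits). Compound 2 `CC(=O)OCCOn1cnc2c(Cl)nc(I)nc21` gives 9400 nM in this assay, and the change from compound 1 to compound 2 is an at least 53-fold lower number from compound 1 to compound 2 (1.72 log units; beyond the scatter). Going by the values given here, compound 3 `CC(=O)OC(C)n1cnc2c(N)nc(I)nc21` gives 436000 nM in this assay; it differs from compound 1 in more than one place, so no single step joins them. Compound 4 `CC(=O)OCCOn1cnc2c(S)nc(N)nc21` differs from compound 1 by sulfanyl in place of chloro on an aromatic carbon. Among the compounds with values here, the one measured step swaps the amino group for iodo and leaves the chloro untouched, so no measured step speaks directly to this change, and no step beyond the scatter is expected. The estimate for compound 4 in this assay is 400000 nM, expected to lie between 50000 nM and 3000000 nM. The expected step is an at least 1.2-fold lower number from compound 1 to compound 4 (0.09 log units; that floor lies within the scatter).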

Compound 4, half-maximal inhibitory concentration: 8900 nM
Compound 4: middle estimate off by 45-fold (1.65 log units), on the high side; measured number below the stated range.
By their numbers in this assay, from the lowest: compounds 4 and 2 (each within the scatter of the next); then compound 3. At a limit, above all of these: compound 1.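

In this assay the carbon that carries the chloro group in compound 1 proves sensitive to change: with the amino group kept, sulfanyl there gives a large step (an at least 56-fold lower number from compound 1 to compound 4 (1.74 log units; beyond the scatter)). Until now only replacing the amino group had shown such a step, so a single replacement at either of two places now lowers the number. This step is only a minimum, and its true size stays unknown because compound 1 sits at a limit: the limit of > 500000 nM in this assay, at which 1 of the 4 values shown sits.

Still open, going by these compounds, is whether another group on this carbon, such as methoxy or methylsulfanyl, would do the same. Also open, on these data alone, is what sulfanyl and iodo would give together on the shared core.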